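The compounds below may be only part of what the source reports. "The series", "measured", "known", "first", "only" and "open" are said of these compounds alone.

Series notes. Compound 1 `CCCCC[Se]c1nc([Se]CCCCC)c2ccccc2n1` gives 38400 nM in a functional assay on MCF7 cells (Homo sapiens) for cytotoxicity, read by MTT assay, with a stated time of 72 h; on this read-out higher numbers stand for weaker inhibition of growth and lower numbers for stronger inhibition of growth. Compound 2 `CSc1nc(NCCCc2ccccc2)c2ccccc2n1` gives 77200 nM in this assay, and compound 3 `CSc1nc(NCCCCc2ccccc2)c2ccccc2n1` gives 32000 nM. Compound 3 carries the lowest of the three numbers; its gap to compound 1 falls within the scatter, so no order between those two is claimed, while its gap to compound 2 lies beyond the scatter. Within the data shown here, the only measured step, a 2.4-fold lower number from compound 2 to compound 3 (0.38 log units; beyond the scatter), goes with benzyl in place of phenyl on a saturated chain carbon, three bonds along the chain from a nitrogen on an aromatic ring.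

Compound 4 `CSc1nc(NCCCCCO)c2ccccc2n1` differs from compound 3 as follows: hydroxymethyl in place of phenyl on a saturated chain carbon, four bonds along the chain from a nitrogen on an aromatic ring. Among the measured compounds shown here, no measured pair carries this exchange. The step from compound 2 to compound 3 concerns only the length of the chain, the phenyl staying at its end, so it bears on the present change only loosely and sets the scale of what one chain-end alteration has done so far. For compound 4 a higher number in this assay is expected, by about a 1.9-fold higher number from compound 3 to compound 4 (0.27 log units; within the scatter), since the ring is removed rather than moved. Compound 4 is therefore estimated at 60000 nM, with a range from 25000 nM to 150000 nM.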

Compound 4, concentration for 50% growth inhibition: 62000 nM
Estimate against measurement, compound 4: 1.0-fold (0.01 log units) below; low and high end bracket the measured number.
By their numbers in this assay, from the lowest: compounds 3, 1, 4 and 2 (each within the scatter of the next, the first and the last beyond it).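

In this assay replacing phenyl with hydroxymethyl, on a saturated chain carbon, four bonds along the chain from a nitrogen on an aromatic ring, gives a 1.9-fold higher number from compound 3 to compound 4 (0.29 log units; within the scatter) and so removes the six-membered aromatic ring without a change beyond the scatter. Taking the other phenyl chain as the starting point, 2-hydroxyethyl in place of phenyl gives a 1.2-fold lower number from compound 2 to compound 4 (0.10 log units; within the scatter) and also stays within the scatter, so the end of the chain can carry either a ring or no ring with no order claimed between compound 4 and either phenyl compound, although those two phenyl compounds lie beyond the scatter of each other. No measurement at hand accounts for these numbers.

Whether any group at the chain end can move the number well beyond the scatter remains open, since the only two groups shown there are phenyl and the hydroxyl-bearing chain end of compound 4. An amine or a carboxylic acid at that end, or a longer chain ending in the hydroxyl, would show whether this position tolerates change broadly or only in these cases.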